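Removing the Benzyl Group from Compound 1

The source may hold more compounds than are shown below. What is called first, only, known or untested is meant among the compounds shown, and "the series" means these compounds.

Compound 1 `Brc1cnc2[nH]c(-c3cc4ccccc4n3Cc3ccccc3)nc2c1`: "not determined" (no result reported)
Compound 2 `Brc1ccc2[nH]c(-c3cc4ccccc4n3Cc3ccccc3)nc2c1`: 15500 nM
Compound 3 `c1ccc(Cn2c(-c3nc4cccnc4[nH]3)cc3ccccc32)cc1`: "not determined" (no result reported)

In a functional assay on T47D cells (Homo sapiens) for antiproliferative activity, read by MTT assay, with a stated time of 48 h (on this read-out lower numbers stand for stronger inhibition and higher numbers for weaker inhibition), compound 1 has no number to its name: its entry reads "not determined" (no result reported), so it cannot be placed on the scale at all. The same is true of compound 3, whose entry also reads "not determined" (no result reported). Only compound 2 gives a figure, at 15500 nM, and that single value is the only anchor available in this assay.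

The next compound to be tested is compound 4 `Brc1cnc2[nH]c(-c3cc4ccccc4[nH]3)nc2c1`. It is built from compound 1 by one change, (hydrogen in place of benzyl on an aromatic nitrogen), which puts hydrogen in place of benzyl on an aromatic nitrogen. Within the data shown here, no pair of tested compounds shows what this kind of change does, and compound 1 offers no starting number, so any forecast here is a judgment rather than a calculation.

The expectation is a modest step in this assay towards a higher number, meaning weaker inhibition, when compound 4 is set against compound 2 at 15500 nM. The uncertainty is wide, and a result with no single number would not be surprising. For compound 4 the expected value is about 25000 nM, with an estimated range of 7000 nM to 90000 nM.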

Compound 4, half-maximal inhibitory concentration: 21000 nM
Compound 4: the middle estimate sits 1.2-fold (0.08 log units) above what was measured; measured number inside the range.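

In this assay, among these compounds, compound 1 has the entry "not determined" (no result reported), so no step from it to compound 4 can be read. The compounds shown leave open what swapping the benzyl group for hydrogen does to the read-out. No evidence at hand bears on the value of compound 4.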